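A few compounds are considered here, and "the series" means these few. Any claim that something is new, unique, unknown or untested is made for them only; others in the source may bear on it.

Measured so far:
compound 1 `O=C1Nc2ccc(S(=O)(=O)N3CCOCC3)cc2/C1=N/NC(=O)c1ccccc1`; in an ADME assay on WI-38 cells (Homo sapiens) for cytotoxicity, read by sulforhodamine B assay, with a stated time of 24 h (on this read-out higher numbers stand for weaker inhibition and lower numbers for stronger inhibition), compound 1 gives 295000 nM
compound 2 `N#CCC(=O)N/N=C1\C(=O)Nc2ccc(S(=O)(=O)N3CCOCC3)cc21`; in this assay compound 2 gives 302000 nM
compound 3 `O=C1Nc2ccc(S(=O)(=O)N3CCOCC3)cc2/C1=N/NS(=O)(=O)c1ccccc1`; in this assay compound 3 gives 302000 nM

Compound 3 sits within the scatter of both others: no change at the digits printed from compound 2 to compound 3 (within the scatter) and a 1.0-fold higher number from compound 1 to compound 3 (0.01 log units; within the scatter), so no order among the three can be read. Compound 4 `O=C1Nc2ccc(S(=O)(=O)N3CCOCC3)cc2/C1=N/c1ccc(O)cc1` is unmeasured; its change from compound 3 is 4-hydroxyphenyl in place of (phenylsulfonyl)amino on a double-bonded nitrogen. Within the data shown here, the steps that bear on it are the swaps of the group carried by the same double-bonded nitrogen, a 1.0-fold higher number from compound 1 to compound 2 (0.01 log units; within the scatter) and no change at the digits printed from compound 2 to compound 3 (within the scatter), none moving this assay beyond the scatter. The present change is larger than either, yet nothing in the series points to a shift. Compound 4 is therefore expected to give 300000 nM (range 150000 nM to 600000 nM), an expected step of a 1.0-fold lower number from compound 3 to compound 4 (0.00 log units; within the scatter).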

Compound 4, half-maximal inhibitory concentration: 259000 nM
For compound 4 the middle estimate is 1.2-fold (0.06 log units) above the measured one; measured number inside the range.
By their numbers in this assay, from the lowest: compounds 4, 1, 2 and 3 (each within the scatter of the next).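

The earlier swaps all kept an amino nitrogen on the double-bonded nitrogen; 4-hydroxyphenyl replaces that amino link as well, and this assay still shows no shift: a 1.2-fold lower number from compound 3 to compound 4 (0.07 log units; within the scatter), a 1.2-fold lower number from compound 2 to compound 4 (0.07 log units; within the scatter) and a 1.1-fold lower number from compound 1 to compound 4 (0.06 log units; within the scatter). Among these compounds, the read-out at this position therefore stays within the scatter across a wider change than the earlier compounds covered. No evidence is available that bears on this result.

On these data alone, whether an amine or a carboxylic acid in place of the hydroxyl, or a longer chain on the double-bonded nitrogen, would move the number beyond the scatter remains open. The rest of the shared core is identical in all four compounds, so its contribution is also unresolved.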